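Pyridin-2-yl in Place of Phenoxy Under a Cytotoxicity Ceiling

A few compounds are considered here, and "the series" means these few. Any claim that something is new, unique, unknown or untested is made for them only; others in the source may bear on it.

Compound 1 `COc1ccc2[nH]c(C(=O)N3CC(=O)N(Cc4ccccc4)[C@@H](COc4ccccc4)C3)cc2c1` gives in an ADME assay on Vero cells (Chlorocebus sabaeus) for cytotoxicity, with a stated time of 7 days (a lower number here means that less compound is tolerated, a higher number that more compound is tolerated), a limit of > 10000 nM.
Compound 2 `COc1ccc2[nH]c(C(=O)N3CC(=O)N(Cc4ccoc4)[C@@H](Cc4ccccc4)C3)cc2c1` gives in this assay a limit of > 10000 nM.
Compound 3 `COc1cccc(CN2C(=O)CN(C(=O)c3cc4cc(OC)ccc4[nH]3)C[C@@H]2c2ccccc2)c1` gives in this assay a limit of > 10000 nM.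

Compound 1 therefore stands only at a limit in this assay, and the two further values shown are limits as well, all three sitting at the limit of > 10000 nM in this assay, at which 3 of the 3 values shown sit. For the measured compounds named here, no step between measured compounds is available, so no measured difference can be drawn from these three.

Compound 4 `COc1ccc2[nH]c(C(=O)N3CC(=O)N(Cc4ccccc4)[C@@H](Cc4ccccn4)C3)cc2c1` differs from compound 1 by pyridin-2-yl in place of phenoxy on a saturated chain carbon bound to a saturated ring carbon, in words pyridin-2-yl in place of phenoxy on a saturated chain carbon bound to a saturated ring carbon. With every measured value resting at the same limit, nothing in the data points to a direction for this change, and the expected step that the limit leaves unreadable from compound 1 to compound 4 is none beyond the scatter. Compound 4 is accordingly expected to give 20000 nM, with a range from 8000 nM to 60000 nM, most likely reported again only as a limit.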

Compound 4, half-maximal cytotoxic concentration: > 30000 nM
Compound 4 was reported as a limit; the forecaster's own chance of this, stated with the estimate: 80%; middle value at least 1.5-fold (0.17 log units) from the limit.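

For the compounds shown here, compound 1 and compound 4 both stand only at limits in this assay, so no step between them can be read. The compounds shown leave open where any true value lies, and whether pyridin-2-yl in place of phenoxy shifts the half-maximal cytotoxic concentration at all.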